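From oxan-4-yl to 1-(trifluoromethyl)ethoxy on compound 2

This account rests on a few compounds, and the source may have more. Where it says the series, first, only, none or still open, it means among the compounds named here.

In an in vitro ADME assay on microsomes from liver (Homo sapiens) for metabolic stability, tested at 1 uM (on this read-out lower numbers stand for a shorter-lived compound and higher numbers for a longer-lived compound), compound 1 (`CC(C)[C@]1(C(=O)N2C[C@@H]3C[C@H]2CN3C(=O)CC(C)(C)C)CC[C@@H](NC2CCOCC2)C1`) gives > 2 h as a limit of the assay. Compound 2 (`CC(C)[C@]1(C(=O)N2C[C@@H]3C[C@H]2CN3C(=O)C2CCOCC2)CC[C@@H](NC2CCOCC2)C1`) gives > 2 h as a limit too, so it stands without a number. For the measured compounds named here, the only measured step on this carbonyl carbon is a step that the two limits leave unreadable from compound 1 to compound 2 and it yields no size. Compound 3 (`CC(OC(=O)N1C[C@@H]2C[C@H]1CN2C(=O)[C@@]1(C(C)C)CC[C@@H](NC2CCOCC2)C1)C(F)(F)F`) carries 1-(trifluoromethyl)ethoxy in place of oxan-4-yl on a carbonyl carbon. Going by the values given here, the only guide is compound 1 and compound 2 sitting at the limit of > 2 h in this assay, at which 2 of the 2 values shown sit, without a readable step. The estimated move is a step that the limit leaves unreadable from compound 2 to compound 3 and no step beyond the scatter is expected. In this assay compound 3 is estimated at 2.5 h with an expected range of 1 h to 6 h for repeat measurements.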

Compound 3, half-life: 1.3 h
Compound 3: the middle estimate sits 1.9-fold (0.28 log units) above what was measured; low and high end bracket the measured number.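

In this assay compound 3 gives 1.3 h, the first value at this carbonyl carbon that is a number rather than a limit of the assay. 1-(Trifluoromethyl)ethoxy in place of oxan-4-yl gives an at least 1.5-fold lower number from compound 2 to compound 3 (0.18 log units; that floor lies within the scatter), and in place of neopentyl it gives an at least 1.5-fold lower number from compound 1 to compound 3 (0.18 log units; that floor lies within the scatter), so neither step is shown to exceed the scatter. The full size of both steps cannot be read, and the comparison rests on: the limit of > 2 h in this assay, at which 2 of the 3 values shown sit.

Still open, on these data alone, is whether the trifluoromethyl group or the oxygen on the carbonyl carbon goes with the lower number. Plain ethoxy at this carbonyl carbon would separate the two.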